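Swapping a Side Group on a Large Carbon Ring

The source may report more compounds than this note shows. Statements on the series, on what has been measured and on what is new or still open speak of the compounds shown alone.

Compound 1 `COC/C1=C/C[C@](C)(CCC=C(C)C)/C=C/[C@@H](OC(=O)C=C(C)C)[C@](C)(O)/C=C/C1=O` gives 11000 nM in a functional assay on SMMC-7721 cells (Homo sapiens) for antiproliferative activity, read by MTT assay, with a stated time of 48 h (a higher number here means a weaker inhibitor, a lower number a stronger inhibitor), the highest number among the three measured compounds. Compound 2 `CC(C)=CCC[C@]1(C)/C=C/[C@@H](OC(=O)C=C(C)C)[C@](C)(O)/C=C/C(=O)/C(CN(C)C)=C\C1` gives 820 nM and compound 3 `CO/N=C/C1=C/C[C@](C)(CCC=C(C)C)/C=C/[C@@H](OC(=O)C=C(C)C)[C@](C)(O)/C=C/C1=O` gives 3470 nM. Compound 4 `CC(C)=CCC[C@]1(C)/C=C/[C@@H](OC(=O)C=C(C)C)[C@](C)(O)/C=C/C(=O)/C(C(=O)N2CCCC2)=C\C1` differs from compound 1 by (pyrrolidin-1-yl)carbonyl in place of methoxymethyl on a double-bonded ring carbon. Among the compounds with values here, two measured steps bear on it, since both also replace the methoxymethyl group at the same ring carbon: a 13-fold lower number from compound 1 to compound 2 (1.13 log units; beyond the scatter) and a 3.2-fold lower number from compound 1 to compound 3 (0.50 log units; beyond the scatter). Every replacement tried there so far lowered the number, so a drop beyond the scatter is expected here too, in size between those two steps, as a 3.7-fold lower number from compound 1 to compound 4 (0.56 log units; beyond the scatter). Compound 4 is therefore estimated at 3000 nM, with a range from 900 nM to 9000 nM.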

Compound 4, half-maximal inhibitory concentration: 14900 nM
Estimate against measurement, compound 4: 5.0-fold (0.70 log units) below; measured number outside the range, above it.
By their numbers in this assay, from the lowest: compound 2; then compound 3; then compounds 1 and 4 (each within the scatter of the next).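

At this double-bonded ring carbon, not every replacement of methoxymethyl helps in this assay: (pyrrolidin-1-yl)carbonyl gives a 1.4-fold higher number from compound 1 to compound 4 (0.13 log units; within the scatter), so the two groups cannot be told apart. The same group gives a 4.3-fold higher number from compound 3 to compound 4 (0.63 log units; beyond the scatter) and an 18-fold higher number from compound 2 to compound 4 (1.26 log units; beyond the scatter), so the outcome depends on which group enters, and compound 2 keeps the lowest number of the four. No measurement offered here explains these differences.

Still open, going by these compounds, is whether (pyrrolidin-1-yl)methyl, an amine that keeps the ring of compound 4 but has no carbonyl, would match compound 2. How a carboxylic acid on this ring carbon would compare is also unknown.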